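This account rests on a few compounds, and the source may have more. Where it says the series, first, only, none or still open, it means among the compounds named here.

Measured so far:
- compound 1, `Cc1ccc(S(=O)(=O)/N=C(/CCNC2=CC(=O)c3ccccc3C2=O)Nc2cccc(C)c2)cc1`: 10200 nM
- compound 2, `COc1ccc(N/C(CCNC2=CC(=O)c3ccccc3C2=O)=N\S(=O)(=O)c2ccc(C)cc2)cc1OC`: 17800 nM

The two compounds share a core and differ only at the amine nitrogen, where compound 1 carries 3-methylphenyl and compound 2 carries 3,4-dimethoxyphenyl. In a functional assay on DU-145 cells (Homo sapiens) for cytotoxicity, read by MTT assay, with a stated time of 48 h (a lower number here means a stronger inhibitor, a higher number a weaker inhibitor), compound 1 gives 10200 nM and compound 2 gives 17800 nM; the step of a 1.7-fold higher number from compound 1 to compound 2 (0.24 log units; within the scatter) is within the scatter, so neither compound can be set above the other. Among the measured compounds shown here, compound 2 holds the higher of the two numbers in this assay, with compound 1 as its only neighbour.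

Compound 3, `COc1ccc(N/C(CCNC2=CC(=O)c3ccccc3C2=O)=N\S(=O)(=O)c2ccc(C(C)(C)C)cc2)cc1OC`, has not yet been run in this assay. It keeps the 3,4-dimethoxyphenyl of compound 2 and changes the sulfonyl-bearing ring: tert-butyl in place of methyl on an aromatic carbon. For the measured compounds named here, no measured step touches this part of the molecule; the only step on record sits at the amine nitrogen and was within the scatter, so it gives no direction for this change. With nothing to draw on, no step beyond the scatter is expected in this assay for compound 3 ; the expected step is a 1.2-fold lower number from compound 2 to compound 3 (0.07 log units; within the scatter). Compound 3 is estimated at 15000 nM, within a range of 6000 nM to 40000 nM.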

Compound 3, half-maximal inhibitory concentration: 14500 nM
Beside the measured number, compound 3's estimate is 1.0-fold (0.01 log units) above it; the measured number falls inside the stated range.
By their numbers in this assay, from the lowest: compounds 1, 3 and 2 (each within the scatter of the next).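

In this assay, the sulfonyl-bearing ring now has a step of its own: tert-butyl in place of methyl, on an aromatic carbon para to a large group, gives a 1.2-fold lower number from compound 2 to compound 3 (0.09 log units; within the scatter). The entering group has 4 heavy atoms against 1 for the group leaving, yet this step lies within the scatter, so compound 2 and compound 3 cannot be separated, and this alkyl change gives no direction at this position, just as a 1.7-fold higher number from compound 1 to compound 2 (0.24 log units; within the scatter) gave none at the amine nitrogen. Nothing available bears on why this change leaves the reading within the scatter.

Whether this carbon responds at all remains open, as the two groups shown here are both plain alkyl groups, and a carboxylic acid, an amine or a methoxy group in the same place could give a different reading. The tert-butyl group is also shown only with 3,4-dimethoxyphenyl on the amine nitrogen, so its reading alongside 3-methylphenyl, and any dependence between the two places, remain open.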